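The source may report more compounds than this note shows. Statements on the series, on what has been measured and on what is new or still open speak of the compounds shown alone.

Compound 1 `CC1NC(NCC2COc3ccccc3O2)=Nc2ccccc21`: 37 nM
Compound 2 `CC1NC(NC[C@H]2CCCO2)=Nc2ccccc21`: 163 nM

In an assay on isolated protein for binding affinity to 5-hydroxytryptamine receptor 5A (Homo sapiens) (on this read-out lower numbers stand for stronger inhibition and higher numbers for weaker inhibition), compound 1 gives 37 nM, while compound 2 gives 163 nM, the higher of the two numbers and a gap beyond the usual scatter. The step to compound 3 `CNC1=Nc2ccccc2C(C)N1` strips the side group down: hydrogen in place of oxolan-2-yl on a saturated chain carbon bound to an amine nitrogen. Since compound 1, which carries the larger group, shows the lower number, shrinking the group further is expected to push the number upward again by a step beyond the scatter, estimated as a 3.7-fold higher number from compound 2 to compound 3 (0.57 log units; beyond the scatter). For compound 3 the expected value in this assay is 600 nM, with a likely range from 150 nM to 2500 nM.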

Compound 3, inhibition constant: 103 nM
The estimate for compound 3 lay 5.8-fold (0.77 log units) above the measured number; the measured number lies below the stated range.
By their numbers in this assay, from the lowest: compound 1; then compounds 3 and 2 (each within the scatter of the next).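

In this assay, going from (oxolan-2-yl)methyl to methyl gives a 1.6-fold lower number from compound 2 to compound 3 (0.20 log units; within the scatter) and so shows that the oxolan-2-yl group, ring and oxygen included, can leave this saturated chain carbon without a change beyond the scatter. Hydrogen in its place is enough to hold the number at the level of compound 2. No measurement shown here offers an explanation for this. As far as these compounds go, it remains open whether an amine, a carboxylic acid or a longer chain such as butyl on this same carbon would leave the number where it stands or shift it.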